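Swapping the aryl group: a benzothiophene variant of compound 2

A few compounds are considered here, and "the series" means these few. Any claim that something is new, unique, unknown or untested is made for them only; others in the source may bear on it.

Compound 1 `CC(C)(C)n1cc(-c2cc(C(O)(C(F)(F)F)C(F)(F)F)cnc2N2CCN(S(=O)(=O)c3ccc(N)nc3)CC2)cn1`: 86 mL.min-1.g-1
Compound 2 `Cc1csc(-c2cc(C(O)(C(F)(F)F)C(F)(F)F)cnc2N2CCN(S(=O)(=O)c3ccc(N)nc3)CC2)c1`: 29 mL.min-1.g-1
Compound 3 `COc1cncc(-c2cc(C(O)(C(F)(F)F)C(F)(F)F)cnc2N2CCN(S(=O)(=O)c3ccc(N)nc3)CC2)c1`: 44 mL.min-1.g-1

Three compounds sharing one core and differing only in the aryl group on an aromatic carbon have been measured in an ADME assay (liver) for metabolic stability, with Liver microsome (Homo sapiens) as the target, using microsomes and NADPH, with a stated time of 30 min, tested at 1 uM; on this read-out higher numbers stand for fast clearance and lower numbers for slow clearance. Compound 2 gives the lowest number of the three, 29 mL.min-1.g-1; compound 3 sits nearest at 44 mL.min-1.g-1, a gap within the scatter, while compound 1 at 86 mL.min-1.g-1 is furthest away, a step beyond the scatter.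

Compound 4 `Nc1ccc(S(=O)(=O)N2CCN(c3ncc(C(O)(C(F)(F)F)C(F)(F)F)cc3-c3cc4ccccc4s3)CC2)cn1` is not yet measured. It differs from compound 2 in one place: 1-benzothiophen-2-yl in place of 4-methylthiophen-2-yl on an aromatic carbon.

For the measured compounds named here, the steps that bear on this change are those that also exchange the aryl group. a 3.0-fold lower number from compound 1 to compound 2 (0.47 log units; beyond the scatter), whereas a 1.5-fold higher number from compound 2 to compound 3 (0.18 log units; within the scatter) and a 2.0-fold lower number from compound 1 to compound 3 (0.29 log units; within the scatter). None of these exchanges a thiophene for a fused bicyclic aryl, so the direction rests on weaker ground. Given that aryl changes here shifted clearance by modest amounts at most, compound 4 is expected to move upward by about a 2.1-fold higher number from compound 2 to compound 4 (0.32 log units; beyond the scatter), and its value in this assay is estimated at 60 mL.min-1.g-1, between 30 mL.min-1.g-1 and 120 mL.min-1.g-1.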

Compound 4, intrinsic clearance in microsomes: < 14 mL.min-1.g-1
Compound 4 was reported as a limit (the forecaster's own chance of this, stated with the estimate: 5%); middle value at least 4.2-fold (0.63 log units) from the limit.
By their numbers in this assay, from the lowest: compounds 2, 3 and 1 (each within the scatter of the next, the first and the last beyond it). At a limit, below all of these: compound 4.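

In this assay compound 4 is reported as a limit of the assay and not as a number: the limit of < 14 mL.min-1.g-1 in this assay, at which 1 of the 4 values shown sits. Even so, the change at this aromatic carbon has a readable direction, with 1-benzothiophen-2-yl in place of 4-methylthiophen-2-yl giving an at least 2.0-fold lower number from compound 2 to compound 4 (0.31 log units; beyond the scatter), and the same group set against the other two aryl groups giving an at least 3.1-fold lower number from compound 3 to compound 4 (0.49 log units; beyond the scatter) and an at least 6.1-fold lower number from compound 1 to compound 4 (0.78 log units; beyond the scatter). The earlier compounds shown here showed no aryl group at this position with a number below that of compound 2, whereas this result shows that a larger group, with a six-membered aromatic ring of carbon only added to the five-membered one, can go lower.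

As far as these compounds go, how far compound 4 lies beneath its limit stays open, so each of these steps has only a minimum size. Also open, from the compounds shown here alone, is whether a thiophen-2-yl without the methyl, a phenyl or a 1-benzofuran-2-yl at this carbon would give a similarly low number.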